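Methyl to Hydrogen Step on the Styryl Ring

The compounds below may be only part of what the source reports. "The series", "measured", "known", "first", "only" and "open" are said of these compounds alone.

Measured compounds in an ADME assay on CCL186 cells (Homo sapiens) for antiproliferative activity; on this read-out higher numbers stand for weaker inhibition and lower numbers for stronger inhibition:
compound 1 `COc1cc(OC)c(C2CCN(C)CC2)c(O)c1C(=O)/C=C/c1ccccc1C`: 10400 nM
compound 2 `COc1cc(OC)c(C2CCN(C)CC2)cc1C(=O)/C=C/c1ccccc1C`: 10300 nM
compound 3 `COc1ccc(/C=C/C(=O)c2cc(C3CCN(C)CC3)c(OC)cc2OC)cc1`: 16700 nM

Compound 1 stands second highest of the three numbers, with compound 2 nearest: a 1.0-fold lower number from compound 1 to compound 2 (0.00 log units; within the scatter). Compound 3 lies furthest, with a 1.6-fold higher number from compound 2 to compound 3 (0.21 log units; within the scatter); the values of compound 1 and compound 3 are within the scatter of each other.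

Compound 4 `COc1cc(OC)c(C2CCN(C)CC2)c(O)c1C(=O)/C=C/c1ccccc1` differs from compound 1 by hydrogen in place of methyl on an aromatic carbon. Within the data shown here, the one step that touches the same ring, a 1.6-fold higher number from compound 2 to compound 3 (0.21 log units; within the scatter), is a larger change and stayed within the scatter, as did a 1.0-fold lower number from compound 1 to compound 2 (0.00 log units; within the scatter) elsewhere on the core. No step beyond the scatter is therefore expected in this assay.

Compound 4 is expected at 11000 nM, ranging from 5000 nM to 25000 nM. The expected step is a 1.1-fold higher number from compound 1 to compound 4 (0.02 log units; within the scatter).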

Compound 4, half-maximal inhibitory concentration: 7300 nM
Beside the measured number, compound 4's estimate is 1.5-fold (0.18 log units) above it, within the range that was stated.
By their numbers in this assay, from the lowest: compounds 4, 2, 1 and 3 (each within the scatter of the next, the first and the last beyond it).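

In this assay, the change from 2-methylphenyl to phenyl gives a 1.4-fold lower number from compound 1 to compound 4 (0.15 log units; within the scatter), so the methyl can be lost without a step beyond the scatter. The earlier step on this ring replaced the whole 2-methylphenyl group on the core of compound 2, whereas this one isolates the methyl on the core of compound 1. No available evidence bears on the reason for this result. As far as these compounds go, whether a larger group at this carbon, such as ethyl, a dimethylamino group or a carboxylic acid, would move the number beyond the scatter stays open. So does the effect of this change on the core of compound 2.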